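A Smaller Ring on the Sulfur of Compound 1

The source may report more compounds than this note shows. Statements on the series, on what has been measured and on what is new or still open speak of the compounds shown alone.

Compound 1 `Cn1c(-c2ccc(NC(=O)CSc3nc4cc(Cl)ccc4o3)cc2)nc(-c2ccccc2)c1-c1ccccc1` was tested in a functional assay on MCF7 cells (Homo sapiens) for cytotoxicity, read by MTT assay, with a stated time of 24 h, tested at 1.6 ug/mL (a higher number here means a stronger effect of the compound at the concentration tested, a lower number a weaker effect), where compound 1 gives 2.5%. Its relative compound 2 `Cc1ccc2oc(SCC(=O)Nc3ccc(-c4nc(-c5ccccc5)c(-c5ccccc5)n4C)cc3)nc2c1` gives 1.9%, and compound 3 `Cn1nnnc1SCC(=O)Nc1ccc(-c2nc(-c3ccccc3)c(-c3ccccc3)n2C)cc1` gives 34.3%. Among these three numbers compound 1 stands second highest, close to compound 2 and far below compound 3. The step of a number 0.6 percentage points lower from compound 1 to compound 2 (within the scatter) shows that methyl in place of chloro on an aromatic carbon makes no real difference. The steps of a number 31.8 percentage points higher from compound 1 to compound 3 (beyond the scatter) and a number 32.4 percentage points higher from compound 2 to compound 3 (beyond the scatter) show that 1-methyl-1H-tetrazol-5-yl in place of either benzoxazolyl group on the sulfur brings a large rise.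

The unmeasured compound 4 `Cc1nnc(SCC(=O)Nc2ccc(-c3nc(-c4ccccc4)c(-c4ccccc4)n3C)cc2)s1` differs from compound 1 in one place: 5-methyl-1,3,4-thiadiazol-2-yl in place of 5-chloro-1,3-benzoxazol-2-yl on a sulfur. This change likewise removes the 5-chloro-1,3-benzoxazol-2-yl from the sulfur and puts a single five-membered aromatic ring with three hetero atoms there, which resembles what happens in compound 3, though the ring itself is a different one. The two large steps therefore point to a rise of considerable size, while the different ring keeps the expectation uncertain. The step is expected to be a number 19.5 percentage points higher from compound 1 to compound 4 (beyond the scatter), and compound 4 is estimated at 22% in this assay, within a range from 3% to 40%.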

Compound 4, a percentage reported as activity, at one concentration (the size of the read-out at that concentration, not a potency): 37.5%
Beside the measured number, compound 4's estimate is 15.5 percentage points below it; low and high end bracket the measured number.
By their numbers in this assay, from the lowest: compounds 2 and 1 (each within the scatter of the next); then compounds 3 and 4 (each within the scatter of the next).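

In this assay, the change at this sulfur gives a number 35 percentage points higher from compound 1 to compound 4 (beyond the scatter) and, starting from the methyl-bearing benzoxazolyl relative, a number 35.6 percentage points higher from compound 2 to compound 4 (beyond the scatter), so the large rise seen earlier is not tied to the 1-methyl-1H-tetrazol-5-yl group alone: a second single five-membered aromatic ring, 5-methyl-1,3,4-thiadiazol-2-yl, brings it too. Exchanging one single ring for the other gives a number 3.2 percentage points higher from compound 3 to compound 4 (within the scatter), so this assay does not tell these two different rings apart, even though the thiadiazolyl ring brings a sulfur into the group. Across all four compounds the numbers now fall into two groups, with the two benzoxazolyl compounds low and the two compounds carrying a single five-membered ring high, and no compound shown goes against this split.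

Still open, on these data alone, is how a group without a ring, such as a short alkyl chain, an amine or a carboxylic acid, would read on this sulfur, and whether the methyl on the thiadiazolyl ring matters at all. Nothing shown gives a measured reason for the gap between the benzoxazolyl groups and the single rings.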